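The source may hold more compounds than are shown below. What is called first, only, known or untested is meant among the compounds shown, and "the series" means these compounds.

Within the data shown here, compound 3 `Cn1c(=O)c(S(=O)(=O)Nc2ccc(F)cc2)cc2cnc(Nc3ccc4[nH]ccc4c3)nc21` stands second highest of the three numbers measured so far in a functional assay on DU-145 cells (Homo sapiens) for inhibition, read by trypan blue exclusion, with a stated time of 72 h (a lower number here means a stronger inhibitor, a higher number a weaker inhibitor), where compound 3 gives 5000 nM. Compound 1 `Cn1c(=O)c(S(=O)(=O)Cc2ccc(F)cc2)cc2cnc(Nc3ccc4[nH]ccc4c3)nc21` gives 30000 nM and compound 2 `Cn1c(=O)c(S(=O)(=O)c2ccc([N+](=O)[O-])cc2F)cc2cnc(Nc3ccc4[nH]ccc4c3)nc21` gives 400 nM. Compound 4 `Cn1c(=O)c(S(=O)(=O)c2ccc(Br)cc2)cc2cnc(Nc3ccc4[nH]ccc4c3)nc21` has not yet been measured; it differs from compound 3 by 4-bromophenyl in place of (4-fluorophenyl)amino on a sulfonyl sulfur. Among the measured compounds shown here, two measured steps bear on this change. The step of a 6.0-fold lower number from compound 1 to compound 3 (0.78 log units; beyond the scatter) shows the (4-fluorophenyl)sulfamoyl group improving on a benzyl sulfone, while the step of a 13-fold higher number from compound 2 to compound 3 (1.10 log units; beyond the scatter) shows the same sulfamoyl group falling well behind a 2-fluoro-4-nitrophenyl sulfone. Compound 4 carries an aryl sulfone, but a plainer one than compound 2, so a smaller gain is expected, a step of a 3.3-fold lower number from compound 3 to compound 4 (0.52 log units; beyond the scatter). Compound 4 is therefore estimated at 1500 nM, within a range from 400 nM to 5000 nM.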

Compound 4, half-maximal inhibitory concentration: 5000 nM
Compound 4: the middle estimate sits 3.3-fold (0.52 log units) below what was measured, within the range that was stated.
By their numbers in this assay, from the lowest: compound 2; then compounds 3 and 4 (each within the scatter of the next); then compound 1.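

In this assay, the change brings no change at the digits printed from compound 3 to compound 4 (within the scatter), so the hydrogen-bond donor leaves with the (4-fluorophenyl)amino group without any shift in the number for this pair. An aryl group directly on the sulfonyl sulfur does not by itself give the low number, as shown by a 13-fold higher number from compound 2 to compound 4 (1.10 log units; beyond the scatter), although it still improves on 4-fluorobenzyl, with a 6.0-fold lower number from compound 1 to compound 4 (0.78 log units; beyond the scatter). No measurement is available to explain these steps. Still open, from the compounds shown here alone, is whether the nitro group or the fluorine sets 2-fluoro-4-nitrophenyl apart, and how a plain 4-nitrophenyl or a piperidine on the sulfonyl sulfur would compare.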